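Working notes: from compound 3 to compound 4

This account rests on a few compounds, and the source may have more. Where it says the series, first, only, none or still open, it means among the compounds named here.

Among the measured compounds shown here, in a physicochemical assay for solubility (a lower number here means a less soluble compound, a higher number a more soluble compound), compound 3 (`CNC(=O)c1cc(C(=O)NC2CC2)cn(Cc2cccc3[nH]ncc23)c1=O`) gives 10 ug/mL, the lowest reading and the only exact number. Compound 1 (`CNC(=O)c1cc(C(=O)NC2CC2)cn(Cc2cccc(C)c2)c1=O`) reads >= 205 ug/mL, which is a limit. Compound 2 (`CNC(=O)c1cc(C(=O)NC2CC2)cn(Cc2cccc3cn[nH]c23)c1=O`) reads >= 181 ug/mL, also a limit. The measured steps are an at least 20-fold lower number from compound 1 to compound 3 (1.31 log units; beyond the scatter) and an at least 18-fold lower number from compound 2 to compound 3 (1.25 log units; beyond the scatter), both large. Compound 4 (`CNC(=O)c1cc(C(=O)NC2CC2)cn(Cc2cccc3cc[nH]c23)c1=O`) carries 1H-indol-7-yl in place of 1H-indazol-4-yl on a saturated chain carbon bound to an aromatic nitrogen. Its group resembles the 1H-indazol-7-yl of compound 2 most closely, so an at least 18-fold lower number from compound 2 to compound 3 (1.25 log units; beyond the scatter) is the best guide, read in reverse. A large rise in this assay is therefore expected, though possibly a smaller one, with a 9.0-fold higher number from compound 3 to compound 4 (0.95 log units; beyond the scatter) as the estimated step. Compound 4 is estimated at 90 ug/mL, with an expected range of 25 ug/mL to 210 ug/mL.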

Compound 4, solubility: >= 144 ug/mL
Compound 4: a limit, no number; the forecaster's own chance of this, stated with the estimate: 35%; middle value at least 1.6-fold (0.20 log units) from the limit.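

In this assay, 1H-indol-7-yl in place of 1H-indazol-4-yl gives an at least 14-fold higher number from compound 3 to compound 4 (1.15 log units; beyond the scatter), so the low reading does not extend to this group, and among the four compounds it belongs to 1H-indazol-4-yl alone. Compound 4 reads >= 144 ug/mL, which is a limit. Compound 1, compound 2 and compound 4 all carry limits, so the steps among them cannot be read and 3-methylphenyl, 1H-indazol-7-yl and 1H-indol-7-yl cannot be ranked.

On these data alone, it remains open whether the low reading of compound 3 follows the point of attachment of its bicyclic group or the second nitrogen of that group. A 1H-indol-4-yl group on the same carbon would separate the two.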